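The source may hold more compounds than are shown below. What is called first, only, known or untested is meant among the compounds shown, and "the series" means these compounds.

Compound 1 `Nc1nc(Cl)c2ncn(Cc3ccccc3CCl)c2n1` and compound 2 `ClCc1cccc(Cn2cnc3nc(Cl)nc(Cl)c32)c1` share a fused two-ring core with compound 3 `ClCc1ccccc1Cn1cnc2nc(Cl)nc(Cl)c21`, and all three carry a chloromethyl-substituted benzyl group. In a functional assay on RPMI-8226 cells (Homo sapiens) for cytotoxicity, read by sulforhodamine B assay, with a stated time of 48 h (on this read-out lower numbers stand for higher toxicity in this test and higher numbers for lower toxicity in this test), compound 1 gives only a limit, > 100000 nM, not a number. In this assay compound 2 likewise gives only a limit, > 100000 nM. Going by the values given here, for compound 3 the entry in this assay reads "not determined" (no result reported), so it stands between two neighbours for which the only information is the limit of > 100000 nM in this assay, at which 2 of the 3 values shown sit, with nothing of its own to place beside them.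

Among the compounds with values here, compound 4 `ClCc1ccccc1Cn1cnc2ncnc(Cl)c21` is the one compound of the set that has not yet been measured. It differs from compound 3 by hydrogen in place of chloro on an aromatic carbon.

Within the data shown here, no step between measured compounds is available, so nothing here says how this change moves the read-out in this assay. Both measured neighbours sit at the limit, and a change of a single chlorine for hydrogen on the core is not expected to lift the compound clearly out of that region. The expectation for compound 4 is therefore a value in this assay of about 150000 nM, somewhere from 30000 nM to 600000 nM, with a fair chance that again only a limit is reported.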

Compound 4, concentration lethal to 50% of the cells: 50100 nM
Estimate against measurement, compound 4: 3.0-fold (0.48 log units) above; low and high end bracket the measured number.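

Going by these compounds alone, the entry for compound 3 in this assay holds no number, so no step from compound 3 to compound 4 can be read, and compound 4 stands at 50100 nM without a measured partner. The compounds shown leave open how replacing chloro with hydrogen on the shared core moves the lethal concentration in this assay.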